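A few compounds are considered here, and "the series" means these few. Any claim that something is new, unique, unknown or untested is made for them only; others in the source may bear on it.

In a functional assay on HeLa cells (Homo sapiens) for inhibition (on this read-out lower numbers stand for stronger inhibition and higher numbers for weaker inhibition), three compounds sharing one core have been measured. Compound 1 `Oc1cccc(-c2cc(-c3cccc(F)c3)cc(-c3cccc(O)c3)n2)c1` gives 1400 nM. Compound 2 `Oc1ccc(-c2cc(-c3cccc(F)c3)cc(-c3cccc(O)c3)n2)cc1` gives 14200 nM, the higher of the two actual numbers. Compound 3 `Oc1ccc(-c2cc(-c3cccc(F)c3)cc(-c3ccc(O)cc3)n2)cc1` is reported only as a limit, > 50000 nM.

Both measured steps are the same exchange, 4-hydroxyphenyl in place of 3-hydroxyphenyl. The first brings a 10-fold higher number from compound 1 to compound 2 (1.01 log units; beyond the scatter), a large step, and the second brings an at least 3.5-fold higher number from compound 2 to compound 3 (0.54 log units; beyond the scatter), at least a modest one.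

Compound 4 `Oc1ccc(-c2cc(-c3ccccc3C(F)(F)F)cc(-c3cccc(O)c3)n2)cc1` keeps both hydroxyphenyl groups of compound 2 and changes the third substituent, the one opposite the ring nitrogen: 2-(trifluoromethyl)phenyl in place of 3-fluorophenyl on an aromatic carbon. Neither measured step touches that place. They show that numbers in this assay can move widely among these compounds, but they give no direction for this exchange, and its size remains open.

The estimate therefore starts from compound 2 at 14200 nM, with no step beyond the scatter expected and only a slight lean towards a higher number. The expected change is a 1.3-fold higher number from compound 2 to compound 4 (0.10 log units; within the scatter). For compound 4 the estimated value is 18000 nM, with an expected range from 6000 nM to 50000 nM.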

Compound 4, half-maximal inhibitory concentration: 17400 nM
Beside the measured number, compound 4's estimate is 1.0-fold (0.01 log units) above it; low and high end bracket the measured number.
By their numbers in this assay, from the lowest: compound 1; then compounds 2 and 4 (each within the scatter of the next). At a limit, above all of these: compound 3.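

In this assay, the exchange at the place opposite the ring nitrogen gives a 1.2-fold higher number from compound 2 to compound 4 (0.09 log units; within the scatter), the first step shown at this position. With both hydroxyphenyl groups of compound 2 kept, 2-(trifluoromethyl)phenyl and 3-fluorophenyl are therefore not told apart by this read-out, even though the entering group carries a trifluoromethyl group where the leaving one carries a single fluorine, and this stands in contrast to the hydroxyphenyl exchange, which gave a 10-fold higher number from compound 1 to compound 2 (1.01 log units; beyond the scatter). None of the information available here bears on why this exchange leaves the number within the scatter.

From the compounds shown here alone, whether the same exchange would also stay within the scatter with the two 3-hydroxyphenyl groups of compound 1 remains open, as this position has been read only with the hydroxyphenyl pair of compound 2. Also open is how a group of another kind at this position, such as an amine, a carboxylic acid or a longer alkyl chain, would read, as only two substituted phenyl groups are shown there.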